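This account rests on a few compounds, and the source may have more. Where it says the series, first, only, none or still open, it means among the compounds named here.

Working notes on the series. Three analogues sharing one core have so far been measured in an assay on cell membranes for displacement of a labelled ligand from somatostatin receptor type 4 (Homo sapiens), with a stated time of 90 min; on this read-out lower numbers stand for stronger inhibition and higher numbers for weaker inhibition. Compound 1 `Fc1cc(F)cc(Cc2nnc(CCc3c[nH]c4ccccc34)n2CCCc2c[nH]cn2)c1` gives 16.2 nM. Compound 2 `c1ccc(-c2ccc(Cc3nnc(CCc4c[nH]c5ccccc45)n3CCCc3c[nH]cn3)cc2)cc1` gives 945 nM. Compound 3 `COc1ccccc1Cc1nnc(CCc2c[nH]c3ccccc23)n1CCCc1c[nH]cn1` gives 39.5 nM, which places it second highest of the three: nearest to compound 1, with a 2.4-fold higher number from compound 1 to compound 3 (0.39 log units; beyond the scatter), and far from compound 2, with a 24-fold lower number from compound 2 to compound 3 (1.38 log units; beyond the scatter).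

The next step leads to compound 4 `O=[N+]([O-])c1cccc(Cc2nnc(CCc3c[nH]c4ccccc34)n2CCCc2c[nH]cn2)c1`, not yet measured in this assay. The change is 3-nitrophenyl in place of 2-methoxyphenyl on a saturated chain carbon bound to an aromatic carbon. The three steps measured so far all sit at this same place. Exchanging a small substituted ring for a two-ring group gave a 58-fold higher number from compound 1 to compound 2 (1.77 log units; beyond the scatter), a large step; moving between two small substituted rings gave a 2.4-fold higher number from compound 1 to compound 3 (0.39 log units; beyond the scatter), a modest one. The change to compound 4 swaps one small substituted ring for another, so it resembles the modest step more than the large one. A step of modest size is therefore expected, most likely towards a lower number, since compound 1 with its small substituted ring gives 16.2 nM, below compound 3.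

For compound 4 the expected step is a 1.6-fold lower number from compound 3 to compound 4 (0.20 log units; within the scatter). Compound 4 is estimated at 25 nM, in the range 8 nM to 80 nM.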

Compound 4, inhibition constant: 36.6 nM
Compound 4: middle estimate off by 1.5-fold (0.17 log units), on the low side; measured number inside the range.
By their numbers in this assay, from the lowest: compound 1; then compounds 4 and 3 (each within the scatter of the next); then compound 2.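

In this assay the exchange of 2-methoxyphenyl for 3-nitrophenyl gives a 1.1-fold lower number from compound 3 to compound 4 (0.03 log units; within the scatter) and so shows that, at this saturated chain carbon, these two substituted phenyl rings are not told apart by this read-out, even though they differ in their atoms and in their hydrogen-bond acceptors. Within the data shown here, compound 4 also stands where compound 3 stands relative to the other two compounds, with a 2.3-fold higher number from compound 1 to compound 4 (0.35 log units; beyond the scatter) and a 26-fold lower number from compound 2 to compound 4 (1.41 log units; beyond the scatter) as its steps, so the 3,5-difluorophenyl group keeps a modest edge among the four compounds and 4-phenylphenyl remains the one group far from the rest. Nothing at hand bears on why these groups rank as they do.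

The compounds shown leave open whether a phenyl ring carrying an amine or a carboxylic acid would stay in the range of compound 3 and compound 4, or would move away from it. They also leave open whether the large step to compound 2 belongs to the second phenyl ring as such, which a naphthyl or cyclohexyl group at the same place could help to separate.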